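This account rests on a few compounds, and the source may have more. Where it says the series, first, only, none or still open, it means among the compounds named here.

Compound 1, `COc1nc(C2CCCCC2)ccc1[C@@H](c1ccccc1)[C@@](O)(CCN(C)C)c1cccc2ccccc12`, gives 57.7 ug/mL in a toxicity assay on HeLa cells (Homo sapiens) for cytotoxicity; on this read-out lower numbers stand for higher toxicity in this test and higher numbers for lower toxicity in this test. This is the highest of the three numbers in hand, yet only its gap to compound 3 lies beyond the scatter. Compound 2, `COc1ncc(-c2ccccc2)cc1[C@@H](c1ccccc1)[C@@](O)(CCN(C)C)c1cc(F)cc(F)c1`, gives 28.8 ug/mL, and compound 3, `COc1ncc(-c2ccccc2)cc1[C@@H](c1ccccc1)[C@@](O)(CCN(C)C)c1cccc(F)c1F`, gives 28.1 ug/mL. Among the measured compounds shown here, the one step between compounds differing in a single place, a 1.0-fold lower number from compound 2 to compound 3 (0.01 log units; within the scatter), concerns a change on a saturated chain carbon and tells nothing about the ring attached to the core.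

Compound 4, `COc1nc(-c2ccc(C#N)cc2)ccc1[C@@H](c1ccccc1)[C@@](O)(CCN(C)C)c1cccc2ccccc12`, differs from compound 1 as follows: 4-cyanophenyl in place of cyclohexyl on an aromatic carbon. For the measured compounds named here, no measured step bears on this change. Going by the values given here, compounds 2 and 3 carry a phenyl on the core while compound 1 carries a cyclohexyl, but they differ from compound 1 in a second place as well, so their values show only that numbers in this range vary within about the scatter. For compound 4 the expected step is therefore a 1.3-fold lower number from compound 1 to compound 4 (0.11 log units; within the scatter), with no direction favoured. Compound 4 is estimated at 45 ug/mL, between 18 ug/mL and 110 ug/mL.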

Compound 4, half-maximal cytotoxic concentration: > 64 ug/mL
Compound 4: only a limit was reported (the forecaster's own chance of this, stated with the estimate: 15%); middle value at least 1.4-fold (0.15 log units) from the limit.
By their numbers in this assay, from the lowest: compounds 3, 2 and 1 (each within the scatter of the next, the first and the last beyond it). At a limit, above all of these: compound 4.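

Among the compounds shown here, at the aromatic carbon next to the ring nitrogen, the exchange of cyclohexyl for 4-cyanophenyl gives the first direct reading of this position in this assay, and it is an at least 1.1-fold higher number from compound 1 to compound 4 (0.04 log units; that floor lies within the scatter). Compound 4 gives only a limit, not a number: the limit of > 64 ug/mL in this assay, at which 1 of the 4 values shown sits. The change therefore does not bring the number down, but only a floor is known for the step, and that floor does not separate compound 4 from compound 1.

The compounds shown do not separate the nitrile from the aromatic ring that carries it. Going by these compounds, how an amine or a carboxylic acid in place of the nitrile would read in this assay also stays open, as does the true size of the step.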